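Vinyl disulfide sulfoxides: E to Z on the phthalimide analogue

The source may hold more compounds than are shown below. What is called first, only, known or untested is meant among the compounds shown, and "the series" means these compounds.

Measured so far:
compound 1 `C=CCSSC=CC[S+]([O-])Cc1ccccc1`: 8900 nM
compound 2 `C=CCSS/C=C/C[S+]([O-])CCCN1C(=O)c2ccccc2C1=O`: 68000 nM
compound 3 `COc1ccc(CSC=CCSCc2ccc(OC)cc2)cc1`: > 200000 nM (a limit of the assay, not a number)

All values come from a functional assay on WHCO1 cells (Homo sapiens) for antiproliferative activity, read by MTT assay, with a stated time of 48 h; on this read-out lower numbers stand for stronger inhibition and higher numbers for weaker inhibition. Compound 2 holds the highest of the two numbers given; compound 1 gives the lower number, and that gap lies beyond the scatter. Compound 3 yields only a limit, at the limit of > 200000 nM in this assay, at which 1 of the 3 values shown sits.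

Compound 4 `C=CCSS/C=C\C[S+]([O-])CCCN1C(=O)c2ccccc2C1=O` remains to be measured. Against compound 2 the difference is: the two compounds have the same atoms and bonds; at least one stereo element is drawn with a configuration in one of them and without one in the other: 1 of 2 stereo elements differ; a double bond is drawn E in compound 2 and Z in compound 4. For the measured compounds named here, no pair of measured compounds differs in one place, so no measured step bears on this change. In this assay the step is expected to be small, none beyond the scatter, in either direction. Compound 4 is expected to give about 60000 nM in this assay. The range expected runs from 20000 nM to 180000 nM. The expected step is a 1.1-fold lower number from compound 2 to compound 4 (0.05 log units; within the scatter).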

Compound 4, half-maximal inhibitory concentration: 33000 nM
Compound 4: the middle estimate sits 1.8-fold (0.26 log units) above what was measured; the measured number falls inside the stated range.
By their numbers in this assay, from the lowest: compound 1; then compound 4; then compound 2. At a limit, above all of these: compound 3.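

In this assay, for the compounds shown here, double-bond geometry alone changes the result, giving the first single-place step: a 2.1-fold lower number from compound 2 to compound 4 (0.31 log units; beyond the scatter). The Z form therefore carries the lower number, although the step is modest and only just beyond the scatter. This comparison carries one qualification: the fact that one of compounds 2 and 4 is drawn with a defined configuration and the other without, at the place where they differ

On these data alone, whether the same E to Z change holds with the other sulfoxide substituent of compound 1 remains open. Also open, as far as these compounds go, is how this position would respond if an amine or a carboxylic acid replaced the phthalimide.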